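Double-bond geometry in the aldehyde-terminated compounds

A few compounds are considered here, and "the series" means these few. Any claim that something is new, unique, unknown or untested is made for them only; others in the source may bear on it.

Going by the values given here, in a functional assay on CCRF-CEM cells (Homo sapiens) for antiproliferative activity (a lower number here means a stronger inhibitor of growth, a higher number a weaker inhibitor of growth), compound 2 `CC(C)(C)C(=O)OCC1(CO)C/C(=C\CCCCCCCCCCCCCCC=O)C(=O)O1` gives 0.933 ug/mL, the only exact number in this small set. Compound 1 `COCCCCCCCCCCCCCCC/C=C1/CC(CO)(COC(=O)C(C)(C)C)OC1=O` gives < 0.1 ug/mL in this assay, and this value is a limit of the assay and not a number. The next comparison is with compound 3 `CC(C)(C)C(=O)OCC1(CO)C/C(=C/CCCCCCCCCCCCCCC=O)C(=O)O1`. The change is the two compounds have the same atoms and bonds; at least one stereo element is drawn with a configuration in one of them and without one in the other: 1 of 2 stereo elements differ; a double bond is drawn E in compound 2 and Z in compound 3: the two compounds have the same atoms and bonds, and a double bond is drawn E in compound 2 and Z in compound 3. Among the compounds with values here, no measured pair shows what this change does, so no shift beyond the usual scatter is expected in this assay, and neither direction is favoured. The expectation is anchored on compound 2 at 0.933 ug/mL. The estimated change is small, a 1.0-fold lower number from compound 2 to compound 3 (0.02 log units; within the scatter). For compound 3 the expected value is 0.9 ug/mL, within an estimated range of 0.3 ug/mL to 2.8 ug/mL.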

Compound 3, concentration for 50% growth inhibition: > 10 ug/mL
Compound 3: no number, only a limit; the forecaster's own chance of this, stated with the estimate: 10%; at least 11-fold (1.04 log units) between middle value and limit.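

Compound 3 gives > 10 ug/mL in this assay, which is a limit of the assay and not a number. Going by these compounds alone, with atoms and bonds unchanged, the double-bond geometry alone gives an at least 10-fold higher number from compound 2 to compound 3 (1.03 log units; beyond the scatter), so this position responds to the drawn configuration, which the earlier compounds could not show. The chain end also matters, with formyl in place of methoxymethyl on a saturated chain carbon giving an at least 100-fold higher number from compound 1 to compound 3 (2.00 log units; beyond the scatter), and the true size of this step stays unresolved: the limit of > 10 ug/mL in this assay, at which 1 of the 3 values shown sits.

From the compounds shown here alone, how cleanly the geometry step compares two defined isomers remains open: the fact that one of compounds 2 and 3 is drawn with a defined configuration and the other without, at the place where they differ Whether the same dependence on geometry holds with a carboxylic acid or an amine at the chain end, or with a longer chain, also remains open.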